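One more fluoro on the difluoromethyl group

This account rests on a few compounds, and the source may have more. Where it says the series, first, only, none or still open, it means among the compounds named here.

Compound 1 `Fc1cc2nc(-c3cncnc3C(F)F)n(C3CC3)c2cc1F` gives 15.3 h here
Compound 2 `N#Cc1ccc2nc(-c3cncnc3C(F)F)n(C3CC3)c2n1` gives 7.5 h here

In an ADME assay on the whole organism (Macaca fascicularis) for metabolic stability, with a stated time of 72 h, at a dose of 1 mg/kg by the oral route (a higher number here means that the compound lasts longer, a lower number that the compound disappears faster), compound 2 gives 7.5 h and so stands lowest of the two, while compound 1 gives 15.3 h and lies ahead of it by a gap beyond the usual scatter. Compound 3 `N#Cc1ccc2nc(-c3cncnc3C(F)(F)F)n(C3CC3)c2n1` differs from compound 2 by a single change (fluoro in place of hydrogen on a saturated chain carbon bound to an aromatic carbon and two fluorine atoms), difluoromethyl to trifluoromethyl, with fluoro in place of hydrogen on a saturated chain carbon bound to an aromatic carbon and two fluorine atoms. Among the compounds with values here, no measured pair shows this change, so its size can only be judged. A small upward move is expected, and none beyond the scatter would be no surprise. The expected step is a 1.3-fold higher number from compound 2 to compound 3 (0.12 log units; within the scatter) and it may well stay within the scatter. In this assay compound 3 is estimated at 10 h with an expected range from 5 h to 20 h around that figure.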

Compound 3, half-life: 5.3 h
The estimate for compound 3 lay 1.9-fold (0.28 log units) above the measured number; the measured number falls inside the stated range.
By their numbers in this assay, from the lowest: compounds 3 and 2 (each within the scatter of the next); then compound 1.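

In this assay, within the data shown here, difluoromethyl to trifluoromethyl gives a 1.4-fold lower number from compound 2 to compound 3 (0.15 log units; within the scatter), the first direct reading of this change at this place. The added fluoro, on a saturated chain carbon bound to an aromatic carbon and two fluorine atoms, therefore leaves the half-life of compound 3 indistinguishable from that of compound 2, so this single swap does not separate the two compounds in this assay. Nothing shown here offers an explanation for this result.

On these data alone, whether the same change would read alike on the core of compound 1 remains open. Also open, as far as these compounds go, is how a group without fluorine at this place, such as a methyl, an ethyl chain or a methoxy group, would compare with difluoromethyl and trifluoromethyl in this assay.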